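A few compounds are considered here, and "the series" means these few. Any claim that something is new, unique, unknown or untested is made for them only; others in the source may bear on it.

Compound 2, `CCCn1c(=O)[nH]c2nc(-c3ccc(S(=O)(=O)N4CCN(c5cccc(F)c5)CC4)cc3)[nH]c2c1=O`, gives 44%. Compound 1, `CCCn1c(=O)c2[nH]c(-c3ccc(S(=O)(=O)N4CCN(c5ccc(Cl)cc5)CC4)cc3)nc2n(CC)c1=O`, gives 28%.

Of the two compounds measured in an assay on CHO cells for displacement of a labelled ligand from adenosine receptor A3 (Homo sapiens), read by scintillation counting, with a stated time of 45 min, tested at 1 uM, in the presence of a further agent that is not named here (on this read-out higher numbers stand for more inhibition at the one concentration tested (going by the name of the read-out) and lower numbers for less inhibition), compound 2 has the higher number and compound 1 the lower, a gap that lies beyond the scatter. Compound 3, `CCCn1c(=O)[nH]c2nc(-c3ccc(S(=O)(=O)N4CCN(Cc5cccc(C)c5)CC4)cc3)[nH]c2c1=O`, has not yet been measured. It differs from compound 2 in one place: 3-methylbenzyl in place of 3-fluorophenyl on an amine nitrogen in a ring. Among the compounds with values here, no pair of measured compounds shows what this change does. A small step downward is expected, a number 9 percentage points lower from compound 2 to compound 3 (within the scatter), though a step within the scatter would not surprise. Compound 3 is therefore expected to give 35%, within a range from 15% to 55%.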

Compound 3, a percentage reported as inhibition, at one concentration (the size of the read-out at that concentration, not a potency): 17%
For compound 3 the middle estimate is 18 percentage points above the measured one; the measured number falls inside the stated range.
By their numbers in this assay, from the lowest: compound 3; then compound 1; then compound 2.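

In this assay, 3-methylbenzyl in place of 3-fluorophenyl on the amine nitrogen in the ring gives a number 27 percentage points lower from compound 2 to compound 3 (beyond the scatter), so the read-out at this position depends on the group it carries. The earlier compounds shown here could not show this, as they differed in more than one place. Nothing given here accounts for the drop. On these data alone, what stays open is whether it goes with the benzyl or with the methyl in place of fluorine. A 3-fluorobenzyl or a 3-methylphenyl group on the same nitrogen would separate the two.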